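Removing a Chloro from a Dichloropurine Cytotoxic Agent

A few compounds are considered here, and "the series" means these few. Any claim that something is new, unique, unknown or untested is made for them only; others in the source may bear on it.

Three compounds share a fused two-ring core carrying two chloro groups, with a substituted benzyl arm attached to a ring nitrogen. Compound 1 is `ClCc1cccc(Cn2cnc3c(Cl)nc(Cl)nc32)c1`, compound 2 is `ClCc1cccc(Cn2cnc3nc(Cl)nc(Cl)c32)c1`, and compound 3 is `ClCc1ccccc1Cn1cnc2c(Cl)nc(Cl)nc21`. In a functional assay on MDA-MB-435 cells (Homo sapiens) for cytotoxicity, read by sulforhodamine B assay, with a stated time of 48 h (a higher number here means a weaker inhibitor of growth, a lower number a stronger inhibitor of growth), compound 1 gives 1690 nM, compound 2 gives 1470 nM, and compound 3 gives 1620 nM. Compound 1 has the highest of the three numbers, but each of the others lies within the scatter of it, so the three are indistinguishable on this assay.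

Compound 4, `ClCc1cccc(Cn2cnc3c(Cl)ncnc32)c1`, has not yet been measured. Relative to compound 1 it differs by hydrogen in place of chloro on an aromatic carbon. The change sits on an aromatic carbon of a six-membered aromatic ring with two nitrogens, between two ring nitrogen atoms, meta to the remaining chloro group, with the other three compounds offering no comparable change to guide the expectation.

Within the data shown here, with no measured step of this kind available, a modest step toward a higher number in this assay is expected, though it may well stay within the scatter. Compound 4 is therefore estimated at 2500 nM, with a range from 1000 nM to 6500 nM, which corresponds to an expected step of a 1.5-fold higher number from compound 1 to compound 4 (0.17 log units; within the scatter).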

Compound 4, concentration for 50% growth inhibition: 1690 nM
Estimate against measurement, compound 4: 1.5-fold (0.17 log units) above; low and high end bracket the measured number.
By their numbers in this assay, from the lowest: compounds 2, 3, 1 and 4 (each within the scatter of the next).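

In this assay, among these compounds, hydrogen in place of chloro on this aromatic carbon gives no change at the digits printed from compound 1 to compound 4 (within the scatter), which is the first comparison here between two compounds that differ in one place. The chloro group that sits between two ring nitrogen atoms is therefore not needed for compound 4 to inhibit growth in these cells to the same measured extent as compound 1, and a whole heavy atom can leave this carbon with no detectable cost in this assay. Nothing measured here explains why the number holds steady, so the result describes what happens without giving a reason.

As far as these compounds go, only chloro and hydrogen are seen on this carbon, so it remains open whether a larger or different group, such as an amine, a methoxy group or a longer chain, would also leave the number in place. The compounds shown also do not tell whether hydrogen in place of the remaining chloro group, which lies meta to this position, would be tolerated in the same way.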